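Methoxy replacing trifluoromethyl on the aryl of a pyrazole urea

The source may report more compounds than this note shows. Statements on the series, on what has been measured and on what is new or still open speak of the compounds shown alone.

Measured compounds:
compound 1, `CC(C)(C)c1cc(CNC(=O)Nc2cccc3[nH]ncc23)n(-c2cccc(Cl)c2)n1`, 0.6 nM
compound 2, `CC(C)(C)c1cc(CNC(=O)Nc2cccc3[nH]ncc23)n(-c2ccc(C(F)(F)F)cc2)n1`, 19.6 nM

Both numbers come from an assay on CHO-K1 cells for antagonist activity at transient receptor potential cation channel subfamily V member 1 (Homo sapiens), read by FLIPR and calcium flux, with a stated time of 6 min; on this read-out higher numbers stand for weaker inhibition and lower numbers for stronger inhibition. Compound 1 and compound 2 share the same core and differ only in the ring carried on the aromatic nitrogen; compound 2 stands as the higher of the two numbers, and the step of a 33-fold higher number from compound 1 to compound 2 (1.51 log units; beyond the scatter) separates them.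

Compound 3, `COc1ccc(-n2nc(C(C)(C)C)cc2CNC(=O)Nc2cccc3[nH]ncc23)cc1`, keeps the core of compound 2 and carries the change (methoxy in place of trifluoromethyl on an aromatic carbon), so that the ring on the aromatic nitrogen becomes 4-methoxyphenyl. For the measured compounds named here, no measured step shows methoxy at this place. Going by the values given here, the only step that bears on it is the one from compound 1 to compound 2, which shows that a change of group on this ring can move the number a great deal. Which way the number goes for a methoxy group is not shown by the two compounds, so the expectation is loose: a step of a 2.0-fold lower number from compound 2 to compound 3 (0.29 log units; within the scatter) in this assay, with a wide range. Compound 3 is therefore estimated at 10 nM, between 2 nM and 60 nM.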

Compound 3, inhibition constant: 62.9 nM
For compound 3 the middle estimate is 6.3-fold (0.80 log units) below the measured one; the measured number lies above the stated range.
By their numbers in this assay, from the lowest: compound 1; then compound 2; then compound 3.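

In this assay, methoxy in place of trifluoromethyl on the aromatic carbon gives a 3.2-fold higher number from compound 2 to compound 3 (0.51 log units; beyond the scatter), so the direction of this exchange, which the first two compounds could not show, is toward weaker inhibition. Measured against the 3-chlorophenyl ring, the 4-methoxyphenyl ring gives a 100-fold higher number from compound 1 to compound 3 (2.02 log units; beyond the scatter), a larger step than the one to the 4-(trifluoromethyl)phenyl ring, and so both rings that carry a group at this place stand well above compound 1, although the two groups differ from each other by more than the usual scatter. No accompanying measurement accounts for this order of the three numbers.

What the compounds shown leave open is whether the distance from compound 1 follows from the group itself or from where it sits on the ring, since compound 1 differs from the other two in both respects and a 4-chlorophenyl ring would be needed to separate them. Also open, from the compounds shown here alone, is how an amine or a carboxylic acid on the same aromatic carbon would read in this assay.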